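Acetamido for nitro on the benzodioxane aryl position

The source may report more compounds than this note shows. Statements on the series, on what has been measured and on what is new or still open speak of the compounds shown alone.

Compound 2 `CN1CCC[C@H]1[C@@H]1COc2ccc([N+](=O)[O-])cc2O1` gives 4500 nM in an assay on membranes from HEK293 cells for displacement of a labelled ligand from Neuronal acetylcholine receptor; alpha3/beta4 (Homo sapiens), with a stated time of 5 min (on this read-out lower numbers stand for stronger inhibition and higher numbers for weaker inhibition), the highest number among the three measured compounds. Compound 1 `CN1CCC[C@H]1[C@@H]1COc2ccc(N)cc2O1` gives 19 nM in this assay, and compound 3 `CN1CCC[C@H]1[C@H]1COc2ccc([N+](=O)[O-])cc2O1` gives 2100 nM. The change from amino to nitro was large, a 240-fold higher number from compound 1 to compound 2 (2.37 log units; beyond the scatter), while the configurational change was modest, a 2.1-fold lower number from compound 2 to compound 3 (0.33 log units; beyond the scatter), consistent with the fact that compounds 2 and 3 differ only in the configuration as drawn.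

Compound 4 `CC(=O)Nc1ccc2c(c1)O[C@H]([C@@H]1CCCN1C)CO2` is not yet measured. Relative to compound 2 it carries acetamido in place of nitro on an aromatic carbon. Among the compounds with values here, the only measured step that bears on this position is the amino-to-nitro exchange, a 240-fold higher number from compound 1 to compound 2 (2.37 log units; beyond the scatter), which shows that replacing the amino group with nitro costs a great deal. Acetamido restores one hydrogen-bond donor at that position but is larger than amino, so a step back toward compound 1 is expected, though not all the way. The expected step is a 15-fold lower number from compound 2 to compound 4 (1.18 log units; beyond the scatter). Compound 4 is therefore estimated at 300 nM, with a range from 60 nM to 1500 nM.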

Compound 4, inhibition constant: 1900 nM
Compound 4: middle estimate off by 6.3-fold (0.80 log units), on the low side; the whole stated range lies below it.
By their numbers in this assay, from the lowest: compound 1; then compounds 4 and 3 (each within the scatter of the next); then compound 2.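

Acetamido recovers little of what nitro loses on this aromatic carbon in this assay, with a 2.4-fold lower number from compound 2 to compound 4 (0.37 log units; beyond the scatter) as the whole gain. The amino group does not tolerate acylation: the acetyl on its nitrogen gives a 100-fold higher number from compound 1 to compound 4 (2.00 log units; beyond the scatter), so a nitrogen on this carbon with one hydrogen-bond donor in the acetamido form is not enough to keep the low number of compound 1. Of the three groups seen at this place on the shared core, only amino gives a low number, while nitro and acetamido both leave it far behind. The information at hand offers no explanation for either step.

Open, from the compounds shown here alone, is whether the loss follows the acetyl group as such or any substituent on that nitrogen, which methylamino, dimethylamino or formamido on the same aromatic carbon would separate. Also open, going by these compounds, is whether a hydroxyl group there would behave like amino.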